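The source may report more compounds than this note shows. Statements on the series, on what has been measured and on what is new or still open speak of the compounds shown alone.

The measured compounds in an ADME assay on HEK293 cells (Homo sapiens) for cytotoxicity, read by CCK-8 assay, with a stated time of 48 h; on this read-out lower numbers stand for stronger inhibition and higher numbers for weaker inhibition:
compound 1 `COc1ccc(/C=C\c2cc(OC)c(OC)c(OC)c2)cc1OCc1ccc(CN2CCCC[C@@H]2C(=O)O)cc1` gives 42000 nM.
compound 2 `COc1ccc(/C=C\c2cc(OC)c(OC)c(OC)c2)cc1OCc1ccc(CNCCO)cc1` gives only a limit of the assay, > 50000 nM.
compound 3 `COc1ccc(/C=C\c2cc(OC)c(OC)c(OC)c2)cc1OCc1ccc(CN2CC[C@H](C(=O)O)C2)cc1` gives only a limit of the assay, > 50000 nM.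

Compound 2 thus stands at the limit of > 50000 nM in this assay, at which 2 of the 3 values shown sit, and no number is known for it. Compound 4 `COc1ccc(/C=C\c2cc(OC)c(OC)c(OC)c2)cc1OCc1ccc(CN[C@H](C(=O)O)[C@@H](C)O)cc1` differs from compound 2 by 1-carboxy-2-hydroxypropyl in place of 2-hydroxyethyl on an amine nitrogen. The measured steps that touch compound 2 are an at least 1.1-fold higher number from compound 1 to compound 2 (0.07 log units; that floor lies within the scatter) and a step that the two limits leave unreadable from compound 2 to compound 3, the latter leaving no readable size. Neither shows a move beyond the scatter, so no step beyond the scatter is expected in this assay, and compound 4 may well return only a limit again. Compound 4 is therefore estimated at 50000 nM, between 30000 nM and 100000 nM. That corresponds to an expected step of a number no higher from compound 2 to compound 4 (the limit leaves the size open).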

Compound 4, half-maximal inhibitory concentration: > 50000 nM
Compound 4 ended at the assay's limit; the forecaster's own chance of this, stated with the estimate: 70%; the middle value lies on the limit itself.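

In this assay, 1-carboxy-2-hydroxypropyl in place of 2-hydroxyethyl on the amine nitrogen leaves compound 4 at a limit of the assay, > 50000 nM. The steps to compound 4 from compound 2 and compound 3 cannot be read, and the only readable one is an at least 1.1-fold higher number from compound 1 to compound 4 (0.07 log units; that floor lies within the scatter). This larger chain on the amine nitrogen therefore gives no measurable number, and the limit now covers most of the set: the limit of > 50000 nM in this assay, at which 3 of the 4 values shown sit.

On these data alone, how far compound 2, compound 3 and compound 4 lie beyond that limit stays open. So does whether a longer chain without a carboxylic acid, or a tertiary amine such as dimethylamino, would give a measurable number.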